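Swapping Chloro for Fluoro on a Cytotoxic Scaffold

A few compounds are considered here, and "the series" means these few. Any claim that something is new, unique, unknown or untested is made for them only; others in the source may bear on it.

Measured compounds:
compound 1, `C=CCn1c(=O)/c(=C\c2cccc(Cl)c2)[nH]c(=O)/c1=C\c1ccccc1OC`: 5500 nM
compound 2, `COc1ccccc1/C=c1/[nH]c(=O)/c(=C\c2cccc(Cl)c2Cl)[nH]c1=O`: "not active" (no number reported)

Of the compounds shown here, two that share a core have been tested in a functional assay on HeLa cells (Homo sapiens) for cytotoxicity, read by CCK-8 assay, with a stated time of 72 h; a higher number here means a weaker inhibitor, a lower number a stronger inhibitor. In this assay, among the compounds with values here, compound 1 gives 5500 nM, the only number available. Compound 2 was reported as "not active" (no number reported), so no number stands beside it, and no comparison in size can be drawn between the two.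

Compound 3, `C=CCn1c(=O)/c(=C\c2cccc(F)c2)[nH]c(=O)/c1=C\c1ccccc1OC`, has not yet been measured. It differs from compound 1 in one place: fluoro in place of chloro on an aromatic carbon. Within the data shown here, since no measured pair shows the effect of this change on the shared core, there is nothing to read a direction from; a swap of one halogen for another of this kind would usually be expected to move the result little, and any step is most likely to stay within the normal scatter, with a slight lean toward a weaker inhibitor.

The step from compound 1 to compound 3 is therefore estimated as a 1.5-fold higher number from compound 1 to compound 3 (0.16 log units; within the scatter). Compound 3 is expected to give about 8000 nM in this assay, with a plausible range from 3000 nM to 25000 nM.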

Compound 3, half-maximal inhibitory concentration: 9100 nM
Compound 3: middle estimate off by 1.1-fold (0.06 log units), on the low side; low and high end bracket the measured number.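

Within the data shown here, this is the first pair on the shared core that differs in one place, and in this assay it gives a 1.7-fold higher number from compound 1 to compound 3 (0.22 log units; within the scatter). Going from 3-chlorophenyl to 3-fluorophenyl therefore produces no step that can be told apart from the ordinary variation between repeated measurements, and compound 3 still has a number on the same scale as compound 1. Nothing measured here offers an explanation for this result, so the pair records only what happened with this one swap at this one place on the shared core.

An amine, a carboxylic acid or a trifluoromethyl group on the same aromatic carbon could show whether this place responds to a larger change, since a swap between two halogens tests only a narrow range of groups. From the compounds shown here alone, it also remains open whether the same swap would give a similar result on another core, and compound 2, with no number beside it and more than one difference from compound 1, cannot settle either question.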